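The source may report more compounds than this note shows. Statements on the series, on what has been measured and on what is new or still open speak of the compounds shown alone.

In an ADME assay on L6 cells (Rattus norvegicus) for cytotoxicity, read by resazurin assay, with a stated time of 72 h (a higher number here means a weaker inhibitor, a lower number a stronger inhibitor), compound 3 (`OC(c1ccc(Cl)cc1)(c1cccnc1)c1ccc(Br)cc1F`) gives 79200 nM, while compound 2 (`CC(C)Oc1ccc(C(O)(c2ccc(Cl)cc2)c2cccnc2)cc1`) gives 56600 nM; these two values lie within the scatter of each other. For compound 1 (`OC(c1ccc(Cl)cc1)(c1cccnc1)c1ccccc1F`), the assay reports only a limit, > 100000 nM. All three compounds therefore sit at very high concentrations on this scale.

Among the measured compounds shown here, the one measured step is an at least 1.2-fold lower number from compound 1 to compound 3 (0.10 log units; that floor lies within the scatter), which places bromo in place of hydrogen on an aromatic carbon. It starts from the limit of > 100000 nM in this assay, at which 1 of the 3 values shown sits, so it gives only a floor for the true size of the change.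

Compound 4 (`CC(C)Oc1ccc(C(O)(c2ccc(Cl)cc2)c2cccnc2)c(F)c1`) carries isopropoxy in place of bromo on an aromatic carbon, para to a large group: isopropoxy in place of bromo on an aromatic carbon. Compound 2, at 56600 nM, also carries isopropoxy, and its value lies within the scatter of compound 3 at 79200 nM. No change beyond the scatter is therefore expected in this assay.

The expected step is a 1.3-fold lower number from compound 3 to compound 4 (0.12 log units; within the scatter).

For compound 4, the estimated value is 60000 nM, with an expected range from 25000 nM to 100000 nM.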

Compound 4, half-maximal inhibitory concentration: 58200 nM
The estimate for compound 4 lay 1.0-fold (0.01 log units) above the measured number, within the range that was stated.
By their numbers in this assay, from the lowest: compounds 2, 4 and 3 (each within the scatter of the next). At a limit, above all of these: compound 1.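

In this assay, the swap at this position, para to a large group, gives a 1.4-fold lower number from compound 3 to compound 4 (0.13 log units; within the scatter), so bromo and isopropoxy cannot be told apart here, although isopropoxy brings more heavy atoms and a hydrogen-bond acceptor. Adding the fluoro group to the isopropoxy compound gives a 1.0-fold higher number from compound 2 to compound 4 (0.01 log units; within the scatter), so in this pair the fluoro group leaves the number unchanged within the scatter. Isopropoxy in place of hydrogen gives an at least 1.7-fold lower number from compound 1 to compound 4 (0.23 log units; that floor lies within the scatter), and this is only a floor because the step starts from a limit: the limit of > 100000 nM in this assay, at which 1 of the 4 values shown sits.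

The compounds shown leave open whether an amine or a carboxylic acid at this position would move the number beyond the scatter. From the compounds shown here alone, a longer chain in place of isopropoxy remains equally open, as does the true size of the step from compound 1.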